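The compounds below may be only part of what the source reports. "The series", "measured", "known", "first", "only" and "open" are said of these compounds alone.

Compound 1, `CSc1ncnc2c1c(-c1ccccc1)cn2[C@@H]1O[C@H](CO)[C@@H](O)[C@H]1O`, is the starting point. In a functional assay on CCRF-CEM cells (Homo sapiens), read by MTT assay, with a stated time of 72 h (on this read-out lower numbers stand for stronger inhibition and higher numbers for weaker inhibition), compound 1 gives > 20000 nM, which is a limit of the assay rather than a number. Compound 2, `CNc1ncnc2c1c(-c1ccccc1)cn2[C@@H]1O[C@H](CO)[C@@H](O)[C@H]1O`, differs from it by methylamino in place of methylsulfanyl on an aromatic carbon. In this assay compound 2 gives > 20000 nM, again a limit. The step that the two limits leave unreadable from compound 1 to compound 2 therefore cannot be read. Compound 3, `Cc1nc(N)c2c(-c3ccsc3)cn([C@@H]3O[C@H](CO)[C@@H](O)[C@H]3O)c2n1`, carries a different set of groups on the shared core. In this assay compound 3 gives > 20000 nM, also a limit. On the numbers shown, compound 1 stands where every measured compound stands, at the limit of > 20000 nM in this assay, at which 3 of the 3 values shown sit, so no ranking among compounds 1, 2 and 3 is possible.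

Compound 4, `CSc1ncnc2c1c(-c1cccs1)cn2[C@@H]1O[C@H](CO)[C@@H](O)[C@H]1O`, is not yet measured. It differs from compound 1 by thiophen-2-yl in place of phenyl on an aromatic carbon. Among the measured compounds shown here, no measured step covers this change; the only step that touches compound 1 is a step that the two limits leave unreadable from compound 1 to compound 2, and it is unreadable. For the measured compounds named here, because the limit of > 20000 nM in this assay, at which 3 of the 3 values shown sit, describes all the data, no step of readable size can be drawn from them. Compound 4 is therefore expected to behave like its neighbours, most likely returning a limit again. The estimate for compound 4 is 30000 nM, with a range from 8000 nM to 120000 nM. The expected step that the limit leaves unreadable from compound 1 to compound 4 is thus no change beyond the scatter.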

Compound 4, half-maximal inhibitory concentration: > 20000 nM
Compound 4 was reported as a limit; the forecaster's own chance of this, stated with the estimate: 85%; the middle value is on the limit's open side.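

In this assay compound 4 gives > 20000 nM which is a limit and not a number. The step from compound 1 to compound 4, thiophen-2-yl in place of phenyl, therefore cannot be read: the limit of > 20000 nM in this assay, at which 4 of the 4 values shown sit. The compounds shown leave open whether any change on the shared core gives a readable value in this assay and how these compounds rank.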